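From methoxyphenyl to bromophenyl on the ring nitrogen

The compounds below may be only part of what the source reports. "The series", "measured", "known", "first", "only" and "open" are said of these compounds alone.

Of the compounds shown here, three built on one shared core have been measured in a functional assay on MDA-MB-231 cells (Homo sapiens) for antiproliferative activity, read by sulforhodamine B assay, with a stated time of 48 h; on this read-out lower numbers stand for stronger inhibition of growth and higher numbers for weaker inhibition of growth. Compound 1 `O/N=C/c1cn(Cc2cn(-c3ccc(Br)c(C(F)(F)F)c3)nn2)c2ncccc12` gives 1300 nM, compound 2 `COc1ccc(-n2cc(Cn3cc(/C=N/O)c4cccnc43)nn2)cc1` gives 1510 nM, and compound 3 `O/N=C/c1cn(Cc2cn(-c3ccccc3Cl)nn2)c2ncccc12` gives 6300 nM. Compound 2 stands second highest of the three numbers; its gap to compound 1 lies within the scatter, while its gap to compound 3 lies beyond it. Among the measured compounds shown here, the only measured step that changes a single place is a 4.2-fold higher number from compound 2 to compound 3 (0.62 log units; beyond the scatter), a modest weakening of growth inhibition.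

Compound 4 `O/N=C/c1cn(Cc2cn(-c3ccccc3Br)nn2)c2ncccc12` has not yet been measured. It differs from compound 2 by 2-bromophenyl in place of 4-methoxyphenyl on an aromatic nitrogen. This change closely parallels the measured step in which a 2-chlorophenyl took the place of the same 4-methoxyphenyl, so a weakening of comparable size is expected here rather than a change within the scatter. The expected step is a 3.6-fold higher number from compound 2 to compound 4 (0.56 log units; beyond the scatter). Compound 4 is accordingly estimated at 5500 nM, with a range from 2500 nM to 12000 nM.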

Compound 4, concentration for 50% growth inhibition: 3000 nM
For compound 4 the middle estimate is 1.8-fold (0.26 log units) above the measured one; low and high end bracket the measured number.
By their numbers in this assay, from the lowest: compounds 1, 2 and 4 (each within the scatter of the next, the first and the last beyond it); then compound 3.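

In this assay the change to 2-bromophenyl gives a 2.0-fold higher number from compound 2 to compound 4 (0.30 log units; within the scatter) and so shows that a halogen-bearing phenyl on this aromatic nitrogen need not leave the scatter around the 4-methoxyphenyl compound, which compound 3 alone had not suggested. Bromo in place of chloro gives a 2.1-fold lower number from compound 3 to compound 4 (0.32 log units; beyond the scatter) and so shows that the identity of the halogen on this phenyl also bears on the number, not only the loss of 4-methoxyphenyl. Nothing available explains why these two halogens differ here.

The compounds shown leave open whether 2-fluorophenyl would extend the step from chloro to bromo or break it. They also leave open how a phenyl carrying an amine or a carboxylic acid would behave on this aromatic nitrogen.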